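A few compounds are considered here, and "the series" means these few. Any claim that something is new, unique, unknown or untested is made for them only; others in the source may bear on it.

In a functional assay on HCT-116 cells (Homo sapiens) for inhibition, read by MTT assay, with a stated time of 24 h, tested at 10 uM (a higher number here means more inhibition of growth at the concentration tested, a lower number less inhibition of growth), three compounds sharing one core have been measured. Compound 1 `O=c1c(-c2nnc(-c3ccc(Cl)cc3)o2)c[nH]c2ncc(-c3cccnc3)cc12` gives 11.8% in this assay, compound 2 `CS(=O)(=O)c1ccc(-c2cnc3[nH]cc(-c4nnc(-c5cccnc5)o4)c(=O)c3c2)cc1` gives 14.7%, and compound 3 `O=c1c(-c2nnc(-c3ccc(F)cc3)o2)c[nH]c2ncc(-c3ccncc3)cc12` gives 20.5%. The number for compound 2 sits between those of compound 1 and compound 3, and both gaps lie within the usual scatter of repeated measurements, so the three cannot be told apart. Compound 4 `Cc1ccc(-c2nnc(-c3c[nH]c4ncc(-c5ccc(S(C)(=O)=O)cc5)cc4c3=O)o2)cc1` has not yet been measured; it differs from compound 2 by 4-methylphenyl in place of pyridin-3-yl on an aromatic carbon. Within the data shown here, no measured pair shows this change, so the expected step from compound 2 to compound 4 is a number 1.3 percentage points higher from compound 2 to compound 4 (within the scatter), a step not beyond the scatter in either direction. Compound 4 is therefore expected to give about 16% in this assay, somewhere between 5% and 30%.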

Compound 4, percent growth inhibition at one concentration: 24.4%
Beside the measured number, compound 4's estimate is 8.4 percentage points below it, and the stated range covers the measured number.
By their numbers in this assay, from the lowest: compounds 1, 2, 3 and 4 (each within the scatter of the next, the first and the last beyond it).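

In this assay, among these compounds, 4-methylphenyl in place of pyridin-3-yl on the five-membered aromatic ring gives a number 9.7 percentage points higher from compound 2 to compound 4 (within the scatter), the only step here between compounds that differ in one place. At this position, then, a carbon-only ring bearing a methyl group can replace a ring containing nitrogen with no change that can be told from the scatter. Nothing available bears on the reason for this result.

Still open, on these data alone, is whether a group of another kind at this position, such as an amine or a carboxylic acid, would shift the number beyond the scatter.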